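Amide variation on the shared core: compound 3

A few compounds are considered here, and "the series" means these few. Any claim that something is new, unique, unknown or untested is made for them only; others in the source may bear on it.

Measured so far:
compound 1, `CC(C)c1c(C(=O)N2CCCC2c2ccccc2)nn(-c2ccc(F)cc2)c1OC[C@@H](O)C[C@@H](O)CC(=O)O`: 14 nM
compound 2, `COc1ccccc1CNC(=O)c1nn(-c2ccc(F)cc2)c(OC[C@@H](O)C[C@@H](O)CC(=O)O)c1C(C)C`: 22 nM

In an assay on microsomes from liver for inhibition of 3-hydroxy-3-methylglutaryl-coenzyme A reductase (Rattus norvegicus) (a higher number here means a weaker inhibitor, a lower number a stronger inhibitor), compound 2 gives 22 nM, the highest of the two numbers; its nearest neighbour is compound 1, and the step of a 1.6-fold higher number from compound 1 to compound 2 (0.20 log units; within the scatter) is within the scatter. Within the data shown here, the only measured step, a 1.6-fold higher number from compound 1 to compound 2 (0.20 log units; within the scatter), exchanges the whole group on the carbonyl carbon and reads as no real change.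

Compound 3, `CC(C)c1c(C(=O)NCc2cccc(Cl)c2)nn(-c2ccc(F)cc2)c1OC[C@@H](O)C[C@@H](O)CC(=O)O`, differs from compound 2 by 3-chlorophenyl in place of 2-methoxyphenyl on a saturated chain carbon bound to an amide-type nitrogen. Among the measured compounds shown here, no measured step covers a substituent exchange on the benzyl ring itself; the one measured step touches the same amide portion and was within the scatter, so it gives no reason to expect a shift beyond the scatter in either direction. The expected outcome is a number close to that of compound 2.

The estimate for compound 3 in this assay is 20 nM, with a range from 8 nM to 50 nM. The expected shift is a 1.1-fold lower number from compound 2 to compound 3 (0.04 log units; within the scatter).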

Compound 3, half-maximal inhibitory concentration: 5.4 nM
For compound 3 the middle estimate is 3.7-fold (0.57 log units) above the measured one, outside the stated range (below it).
By their numbers in this assay, from the lowest: compound 3; then compounds 1 and 2 (each within the scatter of the next).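

In this assay the exchange of 2-methoxyphenyl for 3-chlorophenyl on the saturated chain carbon bound to an amide-type nitrogen gives a 4.1-fold lower number from compound 2 to compound 3 (0.61 log units; beyond the scatter) and so lies beyond the scatter, which shows that this part of the amide responds to a change on the aromatic ring. The earlier exchange of the whole group on the carbonyl carbon, a 1.6-fold higher number from compound 1 to compound 2 (0.20 log units; within the scatter), gave no such reading, whereas (3-chlorobenzyl)amino in place of 2-phenylpyrrolidin-1-yl gives a 2.6-fold lower number from compound 1 to compound 3 (0.41 log units; beyond the scatter), so the group on the carbonyl carbon is not indifferent to this assay's number. Nothing available explains the shift in either step.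

The step from 2-methoxyphenyl to 3-chlorophenyl alters the substituent and its ring position together, so the compounds shown do not separate the contribution of each. A plain phenyl ring, or a fluorine or a nitrile in place of the chlorine in 3-chlorophenyl, would show whether the lower number belongs to the chlorine itself or to having any substituent at that position.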